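The compounds below may be only part of what the source reports. "The series", "measured", "known", "first", "only" and "open" are said of these compounds alone.

Compounds measured in an ADME assay on PANC-1 cells (Homo sapiens) for cytotoxicity, read by sulforhodamine B assay, with a stated time of 48 h, tested at 10 uM; on this read-out lower numbers stand for less inhibition and higher numbers for more inhibition at the one concentration tested (going by the name of the read-out):
compound 1, `CCCCCCCCc1cn(C(c2ccccc2)c2cc3cc(Br)ccc3nc2OC)nn1`, gives 12.1%;
compound 2, `COc1nc2ccc(Br)cc2cc1C(c1ccccc1)n1cc(CCCO)nn1`, gives 25.5%;
compound 3, `CCCc1cn(C(c2ccccc2)c2cc3cc(Br)ccc3nc2OC)nn1`, gives 11.3%.

Compound 3 sits at the bottom of these three numbers, though its gap to compound 1 is within the scatter, so the numbers of these two are taken as level; only compound 2 stands apart from both. The unmeasured compound 4, `COc1nc2ccc(Br)cc2cc1C(c1ccccc1)n1cc(CCCCCO)nn1`, differs from compound 3 as follows: 2-hydroxyethyl in place of hydrogen on a saturated chain carbon, three bonds along the chain from an aromatic carbon The measured steps that speak to this change are a number 14.2 percentage points lower from compound 2 to compound 3 (beyond the scatter) and a number 0.8 percentage points lower from compound 1 to compound 3 (within the scatter). Taken together they suggest that a chain ending in hydroxy at this position goes with more inhibition in this assay than a bare chain or a plain hydrogen, while chain length alone changes little. Compound 4 carries its hydroxy two bonds further out than compound 2 does, so the expected rise is taken as somewhat smaller and less certain. The expected step is a number 8.7 percentage points higher from compound 3 to compound 4 (within the scatter), a modest increase beyond the scatter. Compound 4 is therefore estimated at 20%, within a range from 8% to 32%.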

Compound 4, a percentage reported as inhibition, at one concentration (the size of the read-out at that concentration, not a potency): 19.6%
Compound 4: the middle estimate sits 0.4 percentage points above what was measured; the measured number falls inside the stated range.
By their numbers in this assay, from the lowest: compounds 3, 1, 4 and 2 (each within the scatter of the next, the first and the last beyond it).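

In this assay, the 5-hydroxypentyl chain of compound 4 gives three steps that all lie within the scatter: a number 8.3 percentage points higher from compound 3 to compound 4 (within the scatter), a number 7.5 percentage points higher from compound 1 to compound 4 (within the scatter) and a number 5.9 percentage points lower from compound 2 to compound 4 (within the scatter). Compound 4 therefore cannot be told apart from compound 2, which carries the shorter hydroxy chain, or from compound 1 and compound 3, which carry no hydroxy, although compound 2 stands clear of those two. The clear separation seen with the 3-hydroxypropyl chain of compound 2 is thus neither repeated nor ruled out with the longer hydroxy chain, and nothing available explains these numbers.

The compounds shown leave open whether an amine or a carboxylic acid in place of the hydroxy would change the inhibition at this position. They also leave open how a still longer hydroxy chain would read.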